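Ethyl in Place of Phenyl on the Aromatic Nitrogen

A few compounds are considered here, and "the series" means these few. Any claim that something is new, unique, unknown or untested is made for them only; others in the source may bear on it.

Compound 1 `C/C(=C/c1ccc(Cc2cccnc2)n1C(C)C)C(=O)O` — 2100 nM
Compound 2 `C/C(=C/c1ccc(Cc2cccnc2)n1-c1ccccc1)C(=O)O` — 24000 nM

In a functional assay on microsomes from aorta for inhibition of Thromboxane-A synthase (Homo sapiens), in the presence of a further agent that is not named here (a higher number here means a weaker inhibitor, a lower number a stronger inhibitor), compound 1 gives 2100 nM. Compound 2 gives 24000 nM, the higher of the two numbers measured. Among the compounds with values here, the one step measured so far, an 11-fold higher number from compound 1 to compound 2 (1.06 log units; beyond the scatter), is phenyl in place of isopropyl on an aromatic nitrogen, and it is large.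

Compound 3 `CCn1c(/C=C(/C)C(=O)O)ccc1Cc1cccnc1` is the next compound, and its change from compound 2 is ethyl in place of phenyl on an aromatic nitrogen. This change undoes the earlier one in kind: an alkyl group returns where phenyl stood, though ethyl rather than isopropyl. Within the data shown here, the only step that bears on it is an 11-fold higher number from compound 1 to compound 2 (1.06 log units; beyond the scatter), so compound 3 is expected to move back towards the number of compound 1 by a step of roughly that size, a 9.6-fold lower number from compound 2 to compound 3 (0.98 log units; beyond the scatter). Compound 3 is therefore estimated at 2500 nM in this assay, with a range from 800 nM to 8000 nM.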

Compound 3, half-maximal inhibitory concentration: 42 nM
Beside the measured number, compound 3's estimate is 60-fold (1.77 log units) above it; the measured number lies below the stated range.
By their numbers in this assay, from the lowest: compound 3; then compound 1; then compound 2.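

At this place on the aromatic nitrogen, alkyl groups cannot be treated as one class: ethyl in place of phenyl gives a far larger step (a 570-fold lower number from compound 2 to compound 3 (2.76 log units; beyond the scatter)) than phenyl in place of isopropyl gave. Isopropyl and ethyl themselves stand well apart, since hydrogen in place of methyl on the chain carbon bound to the aromatic nitrogen gives a large step of its own (a 50-fold lower number from compound 1 to compound 3 (1.70 log units; beyond the scatter)), which leaves compound 3 the strongest inhibitor of the three. Nothing available gives a reason for either step.

The compounds shown do not tell whether the number falls further with methyl or hydrogen on the nitrogen, or rises again with a longer chain such as propyl. They also leave open whether ethyl keeps this advantage when an amide replaces the carboxylic acid.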